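A few compounds are considered here, and "the series" means these few. Any claim that something is new, unique, unknown or untested is made for them only; others in the source may bear on it.

Compound 2 `O=C1O[C@H]([C@@H](O)Cn2cc(CNS(=O)(=O)c3ccc(Cl)cc3F)nn2)C(OCc2ccccc2)=C1OCc1ccccc1` gives 39100 nM in a functional assay on A549 cells (Homo sapiens) for antiproliferative activity, read by MTT assay, with a stated time of 72 h; on this read-out higher numbers stand for weaker inhibition and lower numbers for stronger inhibition.
Compound 1 `Cc1ccc(-c2cn(C/C=C3\OC(=O)C(OCc4ccccc4)=C3OCc3ccccc3)nn2)cc1` reaches only a limit of the assay, > 100000 nM.
Compound 3 `COc1ccccc1-c1cn(C/C=C2\OC(=O)C(OCc3ccccc3)=C2OCc2ccccc2)nn1` likewise reaches only a limit, > 100000 nM.

Among the three measured compounds, compound 2 is the one that gives a number; the other two sit at the limit. Among the compounds with values here, the single step that can be set up, a step that the two limits leave unreadable from compound 1 to compound 3, with 2-methoxyphenyl in place of 4-methylphenyl on an aromatic carbon, cannot be read because the limit of > 100000 nM in this assay, at which 2 of the 3 values shown sit, holds both ends of it.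

Compound 4 `O=C1O[C@H]([C@@H](O)Cn2cc(CCCCl)nn2)C(OCc2ccccc2)=C1OCc1ccccc1` differs from compound 2 by 2-chloroethyl in place of ((4-chloro-2-fluorophenyl)sulfonyl)amino on a saturated chain carbon bound to an aromatic carbon. Within the data shown here, no measured step bears on this change: the only step on record lies at another position and is unreadable in any case, and compounds 1 and 3 also differ from compound 2 in the linker to the shared core, so they show no direct comparison. Among the measured compounds shown here, what can be said is that the one compound carrying the sulfonyl group is the one that yields a number. Compound 4, stripped of that group down to 2-chloroethyl, is therefore expected to lose activity, with a step of a 1.5-fold higher number from compound 2 to compound 4 (0.19 log units; within the scatter) that could carry it to the limit. Compound 4 is estimated at 60000 nM, within 20000 nM to 150000 nM.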

Compound 4, half-maximal inhibitory concentration: 29000 nM
The estimate for compound 4 lay 2.1-fold (0.32 log units) above the measured number; the measured number falls inside the stated range.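

In this assay, the change at this saturated chain carbon bound to an aromatic carbon gives a 1.3-fold lower number from compound 2 to compound 4 (0.13 log units; within the scatter). The ((4-chloro-2-fluorophenyl)sulfonyl)amino group, with 12 heavy atoms, one six-membered aromatic ring, one hydrogen-bond donor and two hydrogen-bond acceptors, thus gives way to a 2-chloroethyl group of 3 heavy atoms, with no ring, donor or acceptor, and the two numbers cannot be told apart. The earlier compounds left the sulfonyl group as the only feature seen with a number, but neither compound 2 nor compound 4 stands at the limit, so in this pair a number does not depend on that group or its aromatic ring: the limit of > 100000 nM in this assay, at which 2 of the 4 values shown sit.

Going by these compounds, whether this tolerance extends to other groups at this place remains open, for instance an amine, a carboxylic acid or a longer chain ending in chlorine, any of which could show whether the position responds to change at all. Compounds 1 and 3 differ from compound 2 and compound 4 in more than one place, including the linker to the shared core, so the contribution of that linker also remains unresolved.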